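Removing the amino group from compound 2: expected cytotoxicity

A few compounds are considered here, and "the series" means these few. Any claim that something is new, unique, unknown or untested is made for them only; others in the source may bear on it.

Compound 1 `CC(/C=N/N(C)c1ccc([N+](=O)[O-])cc1)=N\NC(=O)c1ccc(N)cc1`: 51700 nM
Compound 2 `CC(/C=N/Nc1ccc([N+](=O)[O-])cc1)=N\NC(=O)c1ccccc1N`: 29800 nM
Compound 3 `CC(/C=N/Nc1ccc([N+](=O)[O-])cc1)=N\NC(=O)c1ccc(C(F)(F)F)cc1`: 78700 nM

Of the compounds shown here, three have been tested in an ADME assay on J774 cells (Mus musculus, strain BALB/c) for cytotoxicity, read by resazurin assay, with a stated time of 72 h; on this read-out lower numbers stand for higher toxicity in this test and higher numbers for lower toxicity in this test. Compound 2 gives the lowest number of the three, 29800 nM. Its nearest neighbour is compound 1 at 51700 nM, a gap that lies within the scatter of repeated measurements, so the two cannot be ordered against each other. Compound 3, at 78700 nM, lies beyond the scatter from compound 2 and so reads as less toxic in this assay.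

The next compound, compound 4 `CC(/C=N/Nc1ccc([N+](=O)[O-])cc1)=N\NC(=O)c1ccccc1`, has not been measured. It differs from compound 2 in one place: hydrogen in place of amino on an aromatic carbon. Among the compounds with values here, no step between two measured compounds matches this change, so the expectation rests on the spread of the three numbers alone.

Compound 4 is expected to give about 45000 nM in this assay, with a likely range from 22000 nM to 90000 nM. That expectation amounts to a step of a 1.5-fold higher number from compound 2 to compound 4 (0.18 log units; within the scatter), small and upward, sitting close to the scatter rather than clearly beyond it.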

Compound 4, half-maximal cytotoxic concentration: > 100000 nM
Compound 4 gave a limit, no number (the forecaster's own chance of this, stated with the estimate: 15%); middle value at least 2.2-fold (0.34 log units) from the limit.
By their numbers in this assay, from the lowest: compounds 2, 1 and 3 (each within the scatter of the next, the first and the last beyond it). At a limit, above all of these: compound 4.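

In this assay compound 4 gives > 100000 nM, which is a limit of the assay and not a number. Within the data shown here, on this aromatic carbon, ortho to a large group, replacing amino with hydrogen gives an at least 3.3-fold higher number from compound 2 to compound 4 (0.52 log units; beyond the scatter), so here the amino group marks the more toxic member of a one-place pair, a comparison the earlier compounds did not offer. Replacing trifluoromethyl with hydrogen gives an at least 1.2-fold higher number from compound 3 to compound 4 (0.10 log units; that floor lies within the scatter), so compound 3 and compound 4 cannot be ordered, and the full size of both steps remains unknown: the limit of > 100000 nM in this assay, at which 1 of the 4 values shown sits.

Going by these compounds, whether a hydroxyl, a methoxy group or a carboxylic acid on the same aromatic carbon would read like amino or like hydrogen remains open. The compounds shown also leave open whether a methyl group there would keep any of the difference.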